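Replacing Trifluoromethoxy with Trifluoromethylsulfanyl on the Anilide Ring

This account rests on a few compounds, and the source may have more. Where it says the series, first, only, none or still open, it means among the compounds named here.

Three compounds built on one shared core differ only in the group attached to the aromatic ring. For compound 1 `O=C(Nc1cccc(Cl)c1)C(Cl)Cl` the result in a functional assay on BGC-823 cells (Homo sapiens) for antiproliferative activity, read by MTT assay, with a stated time of 72 h (a higher number here means a weaker inhibitor, a lower number a stronger inhibitor), is "not determined" (no result reported). Compound 2 `O=C(Nc1cccc(I)c1)C(Cl)Cl` gives 58800 nM in this assay, and compound 3 `O=C(Nc1cccc(OC(F)(F)F)c1)C(Cl)Cl` gives 142000 nM. Of the two compounds with numbers, compound 3 stands highest, making it the weaker inhibitor of the pair. Among the compounds with values here, the only recorded step leads to it: a 2.4-fold higher number from compound 2 to compound 3 (0.38 log units; beyond the scatter), a modest change for exchanging one ring substituent for another.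

Compound 4 `O=C(Nc1cccc(SC(F)(F)F)c1)C(Cl)Cl` continues this line with a further swap at the same place: (trifluoromethyl)sulfanyl in place of trifluoromethoxy on an aromatic carbon. Within the data shown here, no measured step covers exactly this exchange, so the single step from compound 2 to compound 3 is the only guide, and it shows that trading one group for another at this position moves the number by only a small amount. The same order of change is therefore expected here, with the number for compound 4 expected to sit a little below that of compound 3, a 1.4-fold lower number from compound 3 to compound 4 (0.15 log units; within the scatter), within the range of the measurements seen so far.

The estimate for compound 4 in this assay is 100000 nM, expected to fall between 40000 nM and 250000 nM.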

Compound 4, half-maximal inhibitory concentration: 123000 nM
Estimate against measurement, compound 4: 1.2-fold (0.09 log units) below, and the stated range covers the measured number.
By their numbers in this assay, from the lowest: compound 2; then compounds 4 and 3 (each within the scatter of the next).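

In this assay, exchanging the oxygen of trifluoromethoxy for the sulfur of (trifluoromethyl)sulfanyl gives a 1.2-fold lower number from compound 3 to compound 4 (0.06 log units; within the scatter), so at this place on the ring the two groups cannot be told apart by this read-out. Iodo does stand apart from both, and the new comparison, a 2.1-fold higher number from compound 2 to compound 4 (0.32 log units; beyond the scatter), is a modest step that closely parallels the earlier 2.4-fold higher number from compound 2 to compound 3 (0.38 log units; beyond the scatter); of the three compounds with numbers, compound 2 therefore remains the strongest inhibitor. The data shown offer no measurement that could explain these differences or this similarity.

As far as these compounds go, compound 1 gives "not determined" (no result reported), and steps to it cannot be read, so how chloro compares with the other three groups at this place stays unknown. From the compounds shown here alone, it also remains open whether a quite different group here, such as an amine, a carboxylic acid or a longer chain, would shift the number further than these exchanges do, or whether any such group would bring it well below that of compound 2.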